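The compounds below may be only part of what the source reports. "The series", "measured", "known", "first", "only" and "open" are said of these compounds alone.

Working notes on the series.

In a functional assay on MCF7 cells (Homo sapiens) for cytotoxicity, read by MTT assay, with a stated time of 96 h (on this read-out lower numbers stand for stronger inhibition and higher numbers for weaker inhibition), compound 1 `COc1cc(C(=O)c2cn(-c3ccccc3)cc2-c2ccccc2Cl)cc(OC)c1OC` gives 76 nM. Compound 2 `COc1cc(C(=O)c2cn(-c3ccccc3)cc2-c2ccccc2[N+](=O)[O-])cc(OC)c1OC` differs from compound 1 by nitro in place of chloro on an aromatic carbon; in this assay compound 2 gives 49 nM, a step of a 1.6-fold lower number from compound 1 to compound 2 (0.19 log units; within the scatter). Compound 3 `COc1cc(C(=O)c2cn(-c3ccc(C)cc3)cc2-c2ccccc2Cl)cc(OC)c1OC` differs from compound 1 by methyl in place of hydrogen on an aromatic carbon, which is also how the two cores of the matched pairs differ; in this assay compound 3 gives 180 nM, a step of a 2.4-fold higher number from compound 1 to compound 3 (0.37 log units; beyond the scatter), and compound 3 holds the highest number of the three. Compound 4 `COc1cc(C(=O)c2cn(-c3ccc(C)cc3)cc2-c2ccccc2[N+](=O)[O-])cc(OC)c1OC` is not yet measured; it differs from compound 3 by nitro in place of chloro on an aromatic carbon, the same change as from compound 1 to compound 2, at the same place. The expected step of a 1.6-fold lower number from compound 3 to compound 4 (0.19 log units; within the scatter) rests on the step of a 1.6-fold lower number from compound 1 to compound 2 (0.19 log units; within the scatter), since the change is the same. Compound 4 is estimated at 115 nM, expected between 55 nM and 240 nM.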

Compound 4, half-maximal inhibitory concentration: 65 nM
Compound 4: middle estimate off by 1.8-fold (0.25 log units), on the high side; low and high end bracket the measured number.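

In this assay, nitro in place of chloro gives a 2.8-fold lower number from compound 3 to compound 4 (0.44 log units; beyond the scatter), and this step does not separate from the one on the other core: the same change on two cores in this assay, a 1.6-fold lower number (0.19 log units; within the scatter) from compound 1 to compound 2 and a 2.8-fold lower number (0.44 log units; beyond the scatter) from compound 3 to compound 4, 1.8-fold (0.25 log units) apart, within the scatter of two such steps

Methyl in place of hydrogen gives a 1.3-fold higher number from compound 2 to compound 4 (0.12 log units; within the scatter), and this step likewise does not separate from its earlier counterpart: the same change on two cores in this assay, a 2.4-fold higher number (0.37 log units; beyond the scatter) from compound 1 to compound 3 and a 1.3-fold higher number (0.12 log units; within the scatter) from compound 2 to compound 4, 1.8-fold (0.25 log units) apart, within the scatter of two such steps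

Both changes therefore carry between these two cores within the scatter, but a single pair per core shows neither that the steps are equal in size nor that they would carry to any further core.

Still open, on these data alone, is whether an amine or a carboxylic acid in place of nitro would follow the same step. As far as these compounds go, it is also open whether an ethyl group or a longer chain in place of methyl would do so.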